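The compounds below may be only part of what the source reports. "The series", "measured", "known", "first", "only" and "open" are said of these compounds alone.

Compounds measured so far in a functional assay on CCRF-CEM cells (Homo sapiens) for antiproliferative activity, with a stated time of 72 h; a higher number here means a weaker inhibitor, a lower number a stronger inhibitor:
- compound 1 `OC[C@H]1O[C@@H](n2cnc3c(NCc4cccc(F)c4)ncnc32)[C@H](O)[C@@H]1O` gives 4000 nM
- compound 2 `Cc1cccc(CNc2ncnc3c2ncn3[C@@H]2O[C@H](CO)[C@@H](O)[C@H]2O)c1` gives 19100 nM
- compound 3 `COc1cccc(CNc2ncnc3c2ncn3[C@@H]2O[C@H](CO)[C@@H](O)[C@H]2O)c1` gives 7600 nM

Compound 3 at 7600 nM is not separated from its nearest neighbour, with a 1.9-fold higher number from compound 1 to compound 3 (0.28 log units; within the scatter) shown, while a 2.5-fold lower number from compound 2 to compound 3 (0.40 log units; beyond the scatter) sets it apart from the methyl analogue. Compound 4 `COc1cc(CNc2ncnc3c2ncn3[C@@H]2O[C@H](CO)[C@@H](O)[C@H]2O)cc(OC)c1` differs from compound 3 by methoxy in place of hydrogen on an aromatic carbon as methoxy in place of hydrogen on an aromatic carbon, the change from 3-methoxyphenyl to 3,5-dimethoxyphenyl.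

Among the measured compounds shown here, no measured step puts a group in place of hydrogen. The three available steps only exchange one group for another on the aromatic ring, so they bear on this change indirectly. Even the largest, a 4.8-fold higher number from compound 1 to compound 2 (0.68 log units; beyond the scatter) in size, is only modest. A small step with no firm direction is therefore expected in this assay, leaning slightly upward. An estimated 1.2-fold higher number from compound 3 to compound 4 (0.07 log units; within the scatter) is the expectation, which means no step beyond the scatter. Compound 4 is estimated at 9000 nM with 3500 nM to 25000 nM as the expected range.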

Compound 4, half-maximal inhibitory concentration: > 166000 nM
Compound 4 gave a limit, no number; the forecaster's own chance of this, stated with the estimate: 10%; middle value at least 18-fold (1.26 log units) away from the limit.
By their numbers in this assay, from the lowest: compounds 1 and 3 (each within the scatter of the next); then compound 2. At a limit, above all of these: compound 4.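

In this assay compound 4 gives only a limit, not a number: the limit of > 166000 nM in this assay, at which 1 of the 4 values shown sits.

Adding a second methoxy group, meta to a large group and meta to a methoxy group, gives an at least 21-fold higher number from compound 3 to compound 4 (1.33 log units; beyond the scatter), which is larger than any step among the earlier compounds, where one ring group was only exchanged for another. The 3,5-dimethoxyphenyl compound also stands clear of the other two analogues, with an at least 8.6-fold higher number from compound 2 to compound 4 (0.93 log units; beyond the scatter) and an at least 41-fold higher number from compound 1 to compound 4 (1.61 log units; beyond the scatter), so this position responds sharply to added substitution even though the first methoxy group did not separate compound 3 from compound 1.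

From the compounds shown here alone, each of these steps is a minimum, so the full size of the change remains open. Going by these compounds, whether it belongs to methoxy specifically or to any second group here is also open, and a fluoro, a methyl or an amine at this place would bear on that.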